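The source may report more compounds than this note shows. Statements on the series, on what has been measured and on what is new or still open speak of the compounds shown alone.

Of the compounds shown here, three of a shared core have been tested in an ADME assay on HepG2 cells (Homo sapiens) for cytotoxicity, read by luminescence, CellTiter-Glo and ATP content, with a stated time of 72 h; on this read-out lower numbers stand for an effect already at smaller amounts and higher numbers for an effect only at larger amounts of compound. Compound 1, `CC(C)Cc1ccc2c(NCCCNCc3ccco3)ccnc2c1`, gives 16000 nM in this assay, the highest of the three numbers. Compound 2, `COc1ccc(F)cc1CNCCCNc1ccnc2cc(Cc3cc(C)cc(C)c3)ccc12`, gives 940 nM, and compound 3, `COc1ccc(Oc2ccc3c(NCCCNCc4cccc(OC)c4O)ccnc3c2)cc1`, gives 5500 nM. Compound 1 thus stands furthest from compound 2 and closest to compound 3, with both gaps beyond the usual scatter.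

Compound 4, `Fc1ccc(Oc2ccc3c(NCCCNCc4ccco4)ccnc3c2)cc1`, has not yet been measured. It differs from compound 1 in one place: 4-fluorophenoxy in place of isobutyl on an aromatic carbon. Among the compounds with values here, no two measured compounds differ by exactly this change, so the size of the step can only be estimated. Because compound 1 gives 16000 nM while compound 3 gives 5500 nM, the expectation is that a larger group at this position goes together with a lower number, and a decrease beyond the scatter is expected for the step of a 2.7-fold lower number from compound 1 to compound 4 (0.43 log units; beyond the scatter). Compound 4 is therefore estimated at 6000 nM in this assay, within a range from 2500 nM to 15000 nM.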

Compound 4, half-maximal effective concentration: 16000 nM
Estimate against measurement, compound 4: 2.7-fold (0.43 log units) below; measured number above the stated range.
By their numbers in this assay, from the lowest: compound 2; then compound 3; then compounds 1 and 4 (each within the scatter of the next).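

In this assay, placing 4-fluorophenoxy instead of isobutyl on this aromatic carbon gives no change at the digits printed from compound 1 to compound 4 (within the scatter). Within the data shown here, this position therefore accepts a group of 8 heavy atoms with an aromatic ring and a hydrogen-bond acceptor in place of one of 4 heavy atoms with no ring, and the number stays put, something the earlier compounds could not show, as each differed from the others in more than one place. Nothing measured here explains why the exchange leaves the number unchanged.

The compounds shown leave open whether a group of another kind at this position, such as an amine or a carboxylic acid, would also leave the number unchanged. As far as these compounds go, it also remains open whether this exchange would give the same result with a different group on the side chain.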